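A few compounds are considered here, and "the series" means these few. Any claim that something is new, unique, unknown or untested is made for them only; others in the source may bear on it.

Measured so far:
Compound 1, `CCCCCCCNC(=N)NC(=N)Nc1ccc(F)c(F)c1`: 1800 nM
Compound 2, `CCN(CC)C(=N)NC(=N)Nc1ccc(C(F)(F)F)cc1`: 4300 nM

Both compounds were tested in a functional assay on HCT-116 cells (Homo sapiens) for antiproliferative activity, read by MTT assay, with a stated time of 72 h; a lower number here means a stronger inhibitor, a higher number a weaker inhibitor. Compound 1 gives 1800 nM, the lower of the two numbers, while compound 2 gives 4300 nM, a higher number whose gap from compound 1 lies beyond the scatter. For the measured compounds named here, the two compounds differ in several places at once, so the values show only that compound 1 is the stronger inhibitor of the pair.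

The unmeasured compound 3, `CC(C)CNC(=N)NC(=N)Nc1ccc(F)c(F)c1`, is the analogue of compound 1 with isopropyl in place of hexyl on a saturated chain carbon bound to an amine nitrogen. Going by the values given here, no step between measured compounds isolates this kind of change, so the expectation rests on the shared core alone. The step of a 2.5-fold higher number from compound 1 to compound 3 (0.40 log units; beyond the scatter) is expected to be a moderate weakening, beyond the scatter. Compound 3 is therefore estimated at 4500 nM, with a range from 1500 nM to 14000 nM.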

Compound 3, half-maximal inhibitory concentration: 29700 nM
Estimate against measurement, compound 3: 6.6-fold (0.82 log units) below; the measured number lies above the stated range.
By their numbers in this assay, from the lowest: compound 1; then compound 2; then compound 3.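

In this assay, for the compounds shown here, the exchange of isopropyl for hexyl on a saturated chain carbon bound to an amine nitrogen produces a 17-fold higher number from compound 1 to compound 3 (1.22 log units; beyond the scatter) and is the first step here that isolates a change at this place. With the rest of compound 1 left as it stands, it shows that activity depends strongly on the group held at this position, and that isopropyl is a poor replacement for hexyl. Nothing at hand bears on the reason for this loss.

The compounds shown leave open whether chain length or branching matters more, as a straight butyl chain would separate the two, and whether a chain longer than hexyl, such as octyl, would do better still. They also leave open whether a cyclohexyl ring or a terminal amine would be accepted at this place.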